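This account rests on a few compounds, and the source may have more. Where it says the series, first, only, none or still open, it means among the compounds named here.

Measured in a physicochemical assay for solubility, measured as kinetic solubility; on this read-out higher numbers stand for higher solubility and lower numbers for lower solubility:
- compound 1 `CNC(=O)c1cc(C(=O)N[C@H]2CC[C@H](O)CC2)n([C@@H](C)c2ccc(Cl)cc2)n1`: >= 132 ug/mL, a limit
- compound 2 `CNC(=O)c1cc(C(=O)N[C@H]2CC[C@H](O)CC2)c([C@@H](C)c2cccc(OC)c2)o1`: >= 113 ug/mL, a limit
- compound 3 `CNC(=O)c1cc(C(=O)N[C@H]2CC[C@H](O)CC2)n([C@@H](C)c2cccc(C(F)(F)F)c2)n1`: 7 ug/mL

Compound 2 gives no exact number in this assay, only a limit, >= 113 ug/mL. Compound 1 also gives only a limit, >= 132 ug/mL. Going by the values given here, compound 3 is the one compound here with an exact number, 7 ug/mL.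

The step in question leads from compound 2 to compound 4 `CNC(=O)c1cc(C(=O)N[C@H]2CC[C@H](O)CC2)c([C@@H](C)c2ccc(Cl)cc2)o1`: 4-chlorophenyl in place of 3-methoxyphenyl on a saturated chain carbon bound to an aromatic carbon and a saturated chain carbon. Put simply, 4-chlorophenyl comes in place of 3-methoxyphenyl on a saturated chain carbon bound to an aromatic carbon and a saturated chain carbon.

Among the compounds with values here, no measured step makes this exact swap. The closest exchanges the aryl group on the core of compound 1, a different core from that shared by compound 2 and compound 4: an at least 18-fold lower number from compound 1 to compound 3 (1.27 log units; beyond the scatter). That large step shows that such an exchange can matter on that core, but it does not involve 3-methoxyphenyl.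

Compound 1, which carries the incoming 4-chlorophenyl, sits at its limit of >= 132 ug/mL, so no large fall is expected. A modest fall, perhaps none beyond the scatter, seems likeliest, with the core difference leaving real uncertainty.

For compound 4 the expected value is 70 ug/mL, with an estimated range from 15 ug/mL to 140 ug/mL. This estimate means an expected at least 1.6-fold lower number from compound 2 to compound 4 (0.20 log units; that floor lies within the scatter).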

Compound 4, solubility: >= 118 ug/mL
Compound 4 gave a limit, no number; the forecaster's own chance of this, stated with the estimate: 40%; middle value at least 1.6-fold (0.22 log units) from the limit.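

In this assay compound 4 gives >= 118 ug/mL, which is a limit. Compound 2 also gives only a limit, >= 113 ug/mL. With these two limits, no step can be read from compound 2 to compound 4. The compounds shown leave open whether 4-chlorophenyl in place of 3-methoxyphenyl shifts this read-out at all on the shared core, and if so, in which direction and how far.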